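The source may report more compounds than this note shows. Statements on the series, on what has been measured and on what is new or still open speak of the compounds shown alone.

In a functional assay on MIA PaCa-2 cells (Homo sapiens) for inhibition, read by MTT assay (a higher number here means a weaker inhibitor, a lower number a stronger inhibitor), compound 1 `O=C(c1cc2cnc(Nc3ccc(N4CCNCC4)cn3)nc2n1C1CCCC1)N1CCCCC1`, with piperidin-1-yl on the carbonyl carbon, gives 39600 nM. Compound 2 `COc1ccc(NC(=O)c2cc3cnc(Nc4ccc(N5CCNCC5)cn4)nc3n2C2CCCC2)cc1`, carrying (4-methoxyphenyl)amino there, gives 2880 nM, and compound 3 `COc1ccc(NC(=O)c2cc3cnc(Nc4ccc(N5CCNCC5)cn4)nc3n2C2CCCC2)c(OC)c1`, carrying (2,4-dimethoxyphenyl)amino, gives 2230 nM. Exchanging piperidin-1-yl for these groups produced large steps, a 14-fold lower number from compound 1 to compound 2 (1.14 log units; beyond the scatter) and an 18-fold lower number from compound 1 to compound 3 (1.25 log units; beyond the scatter), while the added methoxy produced only a 1.3-fold lower number from compound 2 to compound 3 (0.11 log units; within the scatter). Compound 3 therefore stands level with compound 2 and far from compound 1 on this assay.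

Compound 4 `Cc1ccccc1NC(=O)c1cc2cnc(Nc3ccc(N4CCNCC4)cn3)nc2n1C1CCCC1` has 2-methylphenyl in place of 2,4-dimethoxyphenyl on an amide-type nitrogen. The large steps exchanged piperidin-1-yl for an aromatic group, and compound 4 keeps an aromatic group, so they bear on this change only weakly. Among the measured compounds shown here, the closest precedent is the small step of a 1.3-fold lower number from compound 2 to compound 3 (0.11 log units; within the scatter), although no measured compound carries a methyl group. No change beyond the scatter is therefore expected in this assay. The expected change is a 1.3-fold higher number from compound 3 to compound 4 (0.13 log units; within the scatter). Compound 4 is estimated at 3000 nM, with an expected range of 1200 nM to 7500 nM.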

Compound 4, half-maximal inhibitory concentration: 2500 nM
Estimate against measurement, compound 4: 1.2-fold (0.08 log units) above; measured number inside the range.
By their numbers in this assay, from the lowest: compounds 3, 4 and 2 (each within the scatter of the next); then compound 1.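

In this assay the 2-methylphenyl group on the amide-type nitrogen gives a 1.1-fold higher number from compound 3 to compound 4 (0.05 log units; within the scatter) and also a 1.2-fold lower number from compound 2 to compound 4 (0.06 log units; within the scatter) in the comparison with the 4-methoxyphenyl compound, so a methoxy group on the aromatic ring is not needed to reach this level among these compounds. The large step of a 16-fold lower number from compound 1 to compound 4 (1.20 log units; beyond the scatter) now joins the two earlier ones, and all three compounds with a substituted phenyl on that nitrogen stand well apart from the piperidin-1-yl amide, with no exception among the compounds shown. No measurement offered here accounts for these steps.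

Still open, on these data alone, is whether the aromatic ring itself matters, which a benzyl or cyclohexyl group on the amide-type nitrogen would address. Also open, as far as these compounds go, is how a ring bearing a carboxylic acid or an amine would compare with these methyl and methoxy examples.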